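A Carbamoyl Group Replaces an Aryl Group on the Piperazine Nitrogen

This account rests on a few compounds, and the source may have more. Where it says the series, first, only, none or still open, it means among the compounds named here.

Of the compounds shown here, three that share one core have been measured in a functional assay on cells (T-cell, Homo sapiens) for inhibition; a higher number here means a weaker inhibitor, a lower number a stronger inhibitor. Compound 1 `COc1ccc(-c2cnc3nc(N)nc(N4CCN(C(=O)COc5ccccc5)CC4)c3n2)cc1OC` gives 4 nM, compound 2 `COc1ccc(-c2cnc3nc(N)nc(N4CCN(c5cc(Cl)cc(Cl)c5)CC4)c3n2)cc1OC` gives 3400 nM, and compound 3 `COc1ccc(-c2cnc3nc(N)nc(N4CCN(c5ccc(F)cc5)CC4)c3n2)cc1OC` gives 100 nM. Compound 3 thus stands second highest of the three numbers, with a 25-fold higher number from compound 1 to compound 3 (1.40 log units; beyond the scatter) and a 34-fold lower number from compound 2 to compound 3 (1.53 log units; beyond the scatter).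

Compound 4 `COc1ccc(-c2cnc3nc(N)nc(N4CCN(C(=O)Nc5cccc(C)c5)CC4)c3n2)cc1OC` differs from compound 3 in one place: (3-methylphenyl)carbamoyl in place of 4-fluorophenyl on an amine nitrogen in a ring. The most telling comparison is compound 1, whose group on the same nitrogen is likewise joined through a carbonyl, and that change gave a 25-fold higher number from compound 1 to compound 3 (1.40 log units; beyond the scatter). For the measured compounds named here, a step of similar direction is therefore expected here, namely a 10-fold lower number from compound 3 to compound 4 (1.00 log units; beyond the scatter), though with only one such pair the size is uncertain. Compound 4 is estimated at 10 nM, within a range of 3 nM to 40 nM.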

Compound 4, half-maximal inhibitory concentration: 7 nM
Beside the measured number, compound 4's estimate is 1.4-fold (0.15 log units) above it; the measured number falls inside the stated range.
By their numbers in this assay, from the lowest: compounds 1 and 4 (each within the scatter of the next); then compound 3; then compound 2.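

In this assay the (3-methylphenyl)carbamoyl group brings a 14-fold lower number from compound 3 to compound 4 (1.15 log units; beyond the scatter) and a 490-fold lower number from compound 2 to compound 4 (2.69 log units; beyond the scatter) and so gives a second example, after compound 1, of a group joined through a carbonyl outperforming the aryl groups on this amine nitrogen. The change on the carbonyl carbon itself brings a 1.8-fold higher number from compound 1 to compound 4 (0.24 log units; within the scatter) and lies within the scatter, so (3-methylphenyl)amino and phenoxymethyl cannot be told apart here.

No measured evidence explains this difference between carbonyl-joined and aryl groups. Going by these compounds, it also remains open whether a small group without an aromatic ring, such as methyl or dimethylamino on the carbonyl carbon, would keep this level of inhibition.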